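The source may report more compounds than this note shows. Statements on the series, on what has been measured and on what is new or still open speak of the compounds shown alone.

Measured compounds and their values:

Compound 1 `CCOC(=O)c1cnn(-c2nc(-c3ccccc3Cl)c(C#N)c(=O)n2C)c1N`: in a functional assay, with a stated time of 20 min (on this read-out higher numbers stand for weaker inhibition and lower numbers for stronger inhibition), compound 1 gives 78 ug/mL
Compound 2 `Cn1c(NN)nc(-c2ccco2)c(C#N)c1=O`: in this assay compound 2 gives 64 ug/mL
Compound 3 `CSc1nc(-c2ccc(N(C)C)cc2)c(C#N)c(=O)n1C`: in this assay compound 3 gives 78 ug/mL

All three compounds share a core and differ in the groups attached to it. In this assay the number for compound 1 matches that of compound 3 at the digits shown, and the number for compound 2 lies within the usual scatter of both, so the three measurements cannot be told apart with confidence; none of the three stands out as more or less potent than the others.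

Compound 4 `CCOC(=O)c1cnn(-c2nc(-c3ccccc3F)c(C#N)c(=O)n2C)c1N` has not yet been measured. It is built from compound 1 by a single change: fluoro in place of chloro on an aromatic carbon. Cut one bond further out, the same change reads 2-chlorophenyl to 2-fluorophenyl, the change sitting ortho to a large group on a six-membered aromatic ring of carbon only.

Among the compounds with values here, no pair of measured compounds differs in exactly this way, so there is no measured step to lean on. The expectation is therefore that the step of a 1.0-fold higher number from compound 1 to compound 4 (0.01 log units; within the scatter) stays within the scatter, with no clear direction. On that basis compound 4 is estimated to give 80 ug/mL in this assay, with a range from 40 ug/mL to 160 ug/mL.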

Compound 4, half-maximal inhibitory concentration: 69 ug/mL
For compound 4 the middle estimate is 1.2-fold (0.06 log units) above the measured one; the measured number falls inside the stated range.
By their numbers in this assay, from the lowest: compounds 2, 4, 1 and 3 (each within the scatter of the next).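

In this assay, going from 2-chlorophenyl to 2-fluorophenyl gives a 1.1-fold lower number from compound 1 to compound 4 (0.05 log units; within the scatter) and so stays within the usual scatter of repeated measurements. Within the data shown here, this is the first pair here that differs in one place only, and it gives the first direct reading of this position, ortho to a large group on the aromatic ring: this exchange of one halogen for another does not visibly shift the read-out. Nothing measured here explains why the two compounds read alike.

Going by these compounds, only these two halogens have been compared at this place, so it remains open whether plain hydrogen, a methoxy group, an amine or a carboxylic acid there would move the number beyond the scatter. A single pair also cannot show whether the same exchange would read alike with different groups elsewhere on the shared core.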